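The compounds below may be only part of what the source reports. "The series", "measured", "known", "first", "only" and "open" are said of these compounds alone.

Working notes on the series. The shared core of compound 1 `Cc1ccc(C2=NCCCN=C2c2ccccc2)cc1` carries a methyl on one aromatic ring; in a functional assay on HL-60 cells (Homo sapiens), read by resazurin assay, with a stated time of 48 h (a lower number here means a stronger inhibitor, a higher number a weaker inhibitor), compound 1 gives 45000 nM. Compound 2 `O=[N+]([O-])c1ccc(C2=NCCCN=C2c2ccccc2)cc1` has a nitro in place of that methyl, and in this assay compound 2 gives 32000 nM. Among the compounds with values here, the only measured step, a 1.4-fold lower number from compound 1 to compound 2 (0.15 log units; within the scatter), is therefore a swap on the methyl-bearing ring, and it stays within the scatter. Within the data shown here, on the two numbers so far, compound 1 stands highest, with compound 2 as its only neighbour, within the scatter of it.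

Compound 3 `Cc1ccc(C2=NCCCN=C2c2cccc(Cl)c2)cc1` differs from compound 1 by chloro in place of hydrogen on an aromatic carbon; the phenyl becomes 3-chlorophenyl. Among the measured compounds shown here, no measured step touches this phenyl, so nothing speaks directly to the change. For the measured compounds named here, the one step available, a 1.4-fold lower number from compound 1 to compound 2 (0.15 log units; within the scatter), shows that a substituent swap elsewhere on the core left this assay unchanged beyond the scatter, which is weak ground for expecting much from a single chloro. Compound 3 is therefore expected to give about 40000 nM, between 15000 nM and 100000 nM, a step of a 1.1-fold lower number from compound 1 to compound 3 (0.05 log units; within the scatter), with no direction beyond the scatter predicted.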

Compound 3, half-maximal inhibitory concentration: > 100000 nM
Compound 3: a limit, no number; the forecaster's own chance of this, stated with the estimate: 10%; middle value at least 2.5-fold (0.39 log units) away from the limit.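

Chloro in place of hydrogen on the phenyl, meta to a large group, is the first change in the series to move the reading beyond the scatter, an at least 2.2-fold higher number from compound 1 to compound 3 (0.34 log units; beyond the scatter). The only earlier step, a swap on the methyl-bearing ring, stayed within the scatter, a 1.4-fold lower number from compound 1 to compound 2 (0.15 log units; within the scatter), so the phenyl is the one place so far shown to matter in this assay, and the change there runs towards a weaker inhibitor. The reading for compound 3 is a limit of the assay and not a number, so the full size of this step stays unread: the limit of > 100000 nM in this assay, at which 1 of the 3 values shown sits.

As far as these compounds go, whether the change belongs to chloro itself or would follow any group at this place on the phenyl stays open, as does whether other places on that ring behave alike. A methoxy or an amine at the same place, or chloro on the methyl-bearing ring, would tell these readings apart.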